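The source may hold more compounds than are shown below. What is called first, only, known or untested is meant among the compounds shown, and "the series" means these compounds.

In a functional assay on DU-145 cells (Homo sapiens) for inhibition, read by trypan blue exclusion, with a stated time of 96 h (on this read-out higher numbers stand for weaker inhibition of growth and lower numbers for stronger inhibition of growth), compound 1 `Cc1ccc(S(=O)(=O)/C(=C/c2sccc2C)C(=O)c2ccc(Cl)cc2)cc1` gives 10000 nM. Compound 2 `COc1ccccc1/C=C(/SCc1ccc(Cl)c(Cl)c1)C(=O)c1ccc(Cl)cc1` gives 10000 nM, level with compound 1 at the digits shown. Compound 3 `Cc1ccsc1/C=C(/SCc1ccc(Cl)c(Cl)c1)C(=O)c1ccc(Cl)cc1` gives 50000 nM, which leaves compound 1 and compound 2 sharing the lowest number of the three.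

Compound 4 `Cc1ccc(S(=O)(=O)/C(=C/c2ccc(C)s2)C(=O)c2ccc(Cl)cc2)cc1` differs from compound 1 only on a double-bonded chain carbon bound to a double-bonded chain carbon, with 5-methylthiophen-2-yl in place of 3-methylthiophen-2-yl on a double-bonded chain carbon bound to a double-bonded chain carbon.

Among the compounds with values here, one measured step bears on this place: a 5.0-fold higher number from compound 2 to compound 3 (0.70 log units; beyond the scatter). There, 3-methylthiophen-2-yl replaces 2-methoxyphenyl, and the rest of the molecule is not that of compound 1. This modest step therefore gives only a rough idea of how much the place can matter. Within the data shown here, no measured pair compares the two methylthiophenyl groups, so the data give no direction for the change. No step beyond the scatter is expected in this assay.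

The estimated step is no change at the digits printed from compound 1 to compound 4 (within the scatter). For compound 4 the expected value is 10000 nM, with an estimated range of 3000 nM to 40000 nM.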

Compound 4, concentration for 50% growth inhibition: 50000 nM
Compound 4: the middle estimate sits 5.0-fold (0.70 log units) below what was measured; measured number outside the range, above it.
By their numbers in this assay, from the lowest: compounds 1 and 2 (each within the scatter of the next); then compounds 3 and 4 (each within the scatter of the next).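

On the core of compound 1, 5-methylthiophen-2-yl in place of 3-methylthiophen-2-yl gives a 5.0-fold higher number from compound 1 to compound 4 (0.70 log units; beyond the scatter) in this assay, so this place responds to a change between two groups with the same atoms, joined differently. The earlier step at this place exchanged 2-methoxyphenyl for 3-methylthiophen-2-yl on another core; this one separates the two methylthiophenyl groups directly, with the lower number going with 3-methylthiophen-2-yl. No available measurement accounts for the difference.

On these data alone, whether 5-methylthiophen-2-yl would also give a different number from 3-methylthiophen-2-yl on the core of compound 3 stays open. As far as these compounds go, how an unsubstituted thiophen-2-yl, or a thiophene carrying an amine or a carboxylic acid, would read at this place also stays open.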